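Carbamoylmethyl for Isopropyl: An Expected Fall in Activity

This account rests on a few compounds, and the source may have more. Where it says the series, first, only, none or still open, it means among the compounds named here.

Compound 1, `NCCCC[C@H](NC(=O)CN(c1nc(Cl)nc2[nH]cnc12)C1CC1)C(=O)OCc1ccccc1`: 35.3%
Compound 2, `CC(C)[C@H](NC(=O)CN(c1nc(Cl)nc2[nH]cnc12)C1CC1)C(=O)OCc1ccccc1`: 51.3%

In a functional assay on the whole organism (Tail, strain ICR) with Mus musculus as the target, in the tail flick test, with a stated time of 90 min, at a dose of 25 umol/kg by the oral route (a higher number here means a stronger effect of the compound at the dose given, a lower number a weaker effect), compound 2 gives 51.3%, the higher of the two numbers; the step of a number 16 percentage points higher from compound 1 to compound 2 (beyond the scatter) separates it from compound 1. Compound 3, `NC(=O)C[C@H](NC(=O)CN(c1nc(Cl)nc2[nH]cnc12)C1CC1)C(=O)OCc1ccccc1`, differs from compound 2 in one place: carbamoylmethyl in place of isopropyl on a saturated chain carbon bound to an amide-type nitrogen and a carbonyl carbon. Among the compounds with values here, only one step bears on this, a number 16 percentage points higher from compound 1 to compound 2 (beyond the scatter), where 4-aminobutyl gave way to isopropyl; compound 3 moves the other way, bringing in a group with one hydrogen-bond donor and one acceptor. A modest decrease is therefore expected, a number 15.3 percentage points lower from compound 2 to compound 3 (beyond the scatter). Compound 3 is estimated at 36%, within 18% to 54%.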

Compound 3, a percentage reported as activity, at one dose (the size of the read-out at that dose, not a potency): 32.3%
Beside the measured number, compound 3's estimate is 3.7 percentage points above it, and the stated range covers the measured number.
By their numbers in this assay, from the lowest: compounds 3 and 1 (each within the scatter of the next); then compound 2.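

In this assay carbamoylmethyl does not hold the level of isopropyl on this saturated chain carbon (a number 19 percentage points lower from compound 2 to compound 3 (beyond the scatter)). The carbamoylmethyl and 4-aminobutyl compounds cannot be told apart (a number 3 percentage points lower from compound 1 to compound 3 (within the scatter)), so among these three compounds the two side chains that carry nitrogen sit together below the all-carbon isopropyl. Nothing available gives a reason for this pattern. As far as these compounds go, whether a longer all-carbon chain or a cyclohexyl group would match isopropyl remains open. So does the effect of a carboxylic acid at this place.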